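Swapping phenyl for dimethoxyphenyl on the triazole core

The compounds below may be only part of what the source reports. "The series", "measured", "known", "first", "only" and "open" are said of these compounds alone.

Measured so far:
- compound 1, `C=CCn1c(SCC(=O)Nc2ccc(C(C)=O)cc2)nnc1-c1ccccc1`, 54%
- compound 2, `C=CCn1c(SCC(=O)Nc2ccc(/C(C)=N/O)cc2)nnc1-c1ccccc1`, 73%
- compound 3, `C/C(=N\O)c1ccc(NC(=O)CSc2nnc(-c3ccccc3)n2-c2ccccc2)cc1`, 63%

All three share a core and were tested in a functional assay on the whole organism (strain albino) for inhibition, with Rattus norvegicus as the target, read by paw edema, with stated times of 30 min and 3 h, at a dose of 0.28 mmol/kg by the oral route; on this read-out higher numbers stand for more inhibition at the one dose given (going by the name of the read-out) and lower numbers for less inhibition. Compound 3 stands second highest of the three numbers; its nearest neighbour is compound 1 and its furthest is compound 2, and both gaps lie within the usual scatter, so no order among them can be claimed. Going by the values given here, the one step that stands out is a number 19 percentage points higher from compound 1 to compound 2 (beyond the scatter), which changes the group on the aromatic carbon at the far end of the molecule. The other step, a number 10 percentage points lower from compound 2 to compound 3 (within the scatter), is within the scatter.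

Compound 4, `COc1ccc(-c2nnc(SCC(=O)Nc3ccc(/C(C)=N/O)cc3)n2-c2ccccc2)cc1OC`, differs from compound 3 in one place: 3,4-dimethoxyphenyl in place of phenyl on an aromatic carbon. Neither measured step touches this aryl group on the triazole, so nothing here bears directly on the change, and the only pattern seen, that of the step from compound 2 to compound 3, shows a small variation at a ring position. The change is therefore expected to give no step beyond the scatter, and the expected step is a number 1 percentage points lower from compound 3 to compound 4 (within the scatter). Compound 4 is estimated at 62%, with a range from 45% to 78%.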

Compound 4, a percentage reported as inhibition, in the whole organism at one dose (the size of the read-out at that dose, not a potency): 77%
Beside the measured number, compound 4's estimate is 15 percentage points below it; measured number inside the range.
By their numbers in this assay, from the lowest: compounds 1, 3, 2 and 4 (each within the scatter of the next, the first and the last beyond it).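

Going by these compounds alone, this position, an aromatic carbon between two ring nitrogen atoms of the shared core, stayed the same in all the earlier compounds, so its first change is also the first sign that it matters in this assay. Putting 3,4-dimethoxyphenyl in place of phenyl gives a number 14 percentage points higher from compound 3 to compound 4 (beyond the scatter), which shows that the aryl group here can affect the result, at least with phenyl on the ring nitrogen. Nothing measured here accounts for this step.

A 4-methoxyphenyl or 4-chlorophenyl group at this position could show whether the whole of 3,4-dimethoxyphenyl is needed for the step. On these data alone, it also remains open whether the same swap would give a similar step with allyl on the ring nitrogen, the group carried by compound 2.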